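Bringing back an aromatic ring in place of cyclopropyl

This account rests on a few compounds, and the source may have more. Where it says the series, first, only, none or still open, it means among the compounds named here.

In a functional assay on KYSE-70 cells for antiproliferative activity against KYSE-70 cell line (Homo sapiens), read by MTT assay, with a stated time of 72 h (a higher number here means a weaker inhibitor, a lower number a stronger inhibitor), compound 1 `O=C(Nc1cccc(F)c1)c1cc(=O)[nH]c2cc(Br)ccc12` gives 8900 nM and compound 2 `O=C(Nc1cccc(F)c1)c1cc(=O)[nH]c2cc(-c3ccsc3)ccc12` gives 5100 nM, which makes a 1.7-fold lower number from compound 1 to compound 2 (0.24 log units; within the scatter). Compound 3 `O=C(Nc1cccc(F)c1)c1cc(=O)[nH]c2cc(C3CC3)ccc12` gives > 20000 nM, which is a limit and not a number; it is the limit of > 20000 nM in this assay, at which 1 of the 3 values shown sits.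

Compound 4 `O=C(Nc1cccc(F)c1)c1cc(=O)[nH]c2cc(-c3ccc(F)nc3)ccc12` carries 6-fluoropyridin-3-yl in place of cyclopropyl on an aromatic carbon.

Two measured steps into cyclopropyl bear on this change, read in reverse: an at least 3.9-fold higher number from compound 2 to compound 3 (0.59 log units; beyond the scatter) and an at least 2.2-fold higher number from compound 1 to compound 3 (0.35 log units; beyond the scatter). The closer guide is compound 2, whose thiophen-3-yl is the nearest measured group to the entering ring, with 5100 nM in this assay. This rests on a single ring group, and no pyridine has been measured in the series. A move back towards the range of the measured compounds is expected, with the number falling: an at least 3.3-fold lower number from compound 3 to compound 4 (0.52 log units; beyond the scatter), an estimated step. For compound 4 the estimate is 6000 nM, with an expected range from 2000 nM to 18000 nM.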

Compound 4, half-maximal inhibitory concentration: > 20000 nM
Compound 4 ended at the assay's limit; the forecaster's own chance of this, stated with the estimate: 15%; middle value at least 3.3-fold (0.52 log units) from the limit.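

In this assay compound 4 gives > 20000 nM, which is a limit and not a number. Placing 6-fluoropyridin-3-yl on this aromatic carbon gives an at least 3.9-fold higher number from compound 2 to compound 4 (0.59 log units; beyond the scatter) and an at least 2.2-fold higher number from compound 1 to compound 4 (0.35 log units; beyond the scatter), so an aromatic ring here does not by itself hold the activity of compound 2. The step between compound 3 and compound 4 cannot be read, and cyclopropyl and 6-fluoropyridin-3-yl now stand at the same ceiling: the limit of > 20000 nM in this assay, at which 2 of the 4 values shown sit.

The compounds shown do not separate the ring nitrogen from the fluorine of 6-fluoropyridin-3-yl, and a plain pyridin-3-yl or a 4-fluorophenyl group at this position would address that. On these data alone, how far compound 3 and compound 4 lie beyond the limit also remains open.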